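Carboxyphenyl swap on the shared core: maximal response

The source may report more compounds than this note shows. Statements on the series, on what has been measured and on what is new or still open speak of the compounds shown alone.

Compound 1 `COc1ccc(C(=O)O)cc1-c1cccc(COc2ccc3c(c2)CN(C2CCCC2)C3=O)c1` gives 79.2% in an assay on HEK293 cells for positive allosteric modulation of metabotropic glutamate receptor 2 (Rattus norvegicus), read by thallium flux; on this read-out lower numbers stand for smaller maximal responses and higher numbers for larger maximal responses; compound 2 `Cc1ccc(C(=O)O)cc1-c1cccc(COc2ccc3c(=O)n(C4CCCC4)sc3c2)c1` gives 82.9% in this assay, and the two numbers sit within the scatter of each other, so no separation between them is claimed. Among the compounds with values here, no step between measured compounds is available to rest on. Compound 3 `O=C(O)c1ccc(-c2cccc(COc3ccc4c(c3)CN(C3CCCC3)C4=O)c2)c(Cl)c1` carries 4-carboxy-2-chlorophenyl in place of 5-carboxy-2-methoxyphenyl on an aromatic carbon. Within the data shown here, with only this pair of values as background, the step of a number 2.2 percentage points lower from compound 1 to compound 3 (within the scatter) is expected to be small, no larger than the scatter, with no direction favoured. Compound 3 is therefore estimated at 77%, with a range from 58% to 96%.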

Compound 3, largest response reached (reported as percent of maximum), in percent of the reference or control that the assay uses: 89.4%
Compound 3: the middle estimate sits 12.4 percentage points below what was measured; the range from low to high includes it.
By their numbers in this assay, from the lowest: compounds 1, 2 and 3 (each within the scatter of the next, the first and the last beyond it).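

In this assay, 4-carboxy-2-chlorophenyl in place of 5-carboxy-2-methoxyphenyl gives a number 10.2 percentage points higher from compound 1 to compound 3 (beyond the scatter), the only separation beyond the scatter among the single-place comparisons shown. The maximal response therefore depends on the substituted phenyl group at this aromatic carbon, although the step is modest. Nothing on hand gives a reason for this step. Going by these compounds, how the step divides between the carboxy placement and the chloro-for-methoxy exchange remains open, since both differ together. Also open, on these data alone, is how a nitrile or a fluorine in place of the chlorine would read.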